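Furan-2-yl replacing 4-methoxybenzyl in a limit-bound pair

The source may hold more compounds than are shown below. What is called first, only, known or untested is meant among the compounds shown, and "the series" means these compounds.

Compound 1, `CCOC(=O)c1ccc(-c2nn(Cc3cccc(Cl)c3)c3ccccc23)cc1`, reaches only a limit in a functional assay on cells (Platelet, Homo sapiens) for inhibition; a lower number here means a stronger inhibitor, a higher number a weaker inhibitor: > 10000 nM.
Compound 2, `CCOC(=O)c1ccc(-c2nn(Cc3ccc(OC)cc3)c3ccccc23)cc1`, reaches only a limit: > 10000 nM.

Among the compounds with values here, compound 2 stands at the limit of this assay, and its single measured neighbour sits there too (the limit of > 10000 nM in this assay, at which 2 of the 2 values shown sit). Within the data shown here, the only measured step, a step that the two limits leave unreadable from compound 1 to compound 2, therefore cannot be sized, and no step of known size bears on the change now at hand. Compound 3, `CCOC(=O)c1ccc(-c2nn(-c3ccco3)c3ccccc23)cc1`, differs from compound 2 in one place: furan-2-yl in place of 4-methoxybenzyl on an aromatic nitrogen. With nothing readable to lean on, no direction can be drawn for this change. Because both values shown sit at the limit (the limit of > 10000 nM in this assay, at which 2 of the 2 values shown sit), compound 3 is expected to remain close to that limit, the estimated step being a step that the limit leaves unreadable from compound 2 to compound 3. For compound 3 the estimate is 20000 nM, within a range from 3000 nM to 100000 nM.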

Compound 3, half-maximal inhibitory concentration: > 10000 nM
Compound 3 was reported as a limit; the forecaster's own chance of this, stated with the estimate: 70%; the middle value does not contradict the limit.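

Compound 3 sits at the limit in this assay like compound 1 and compound 2, so neither new step to compound 3 can be read: the limit of > 10000 nM in this assay, at which 3 of the 3 values shown sit.
The compounds shown leave open whether any group on the aromatic nitrogen of the shared core brings a readable inhibition in this assay at all.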